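From 3,4-difluorophenyl to 2-(pyridin-3-yl)ethyl

The source may report more compounds than this note shows. Statements on the series, on what has been measured and on what is new or still open speak of the compounds shown alone.

Values measured in a functional assay on MCF7 cells (Homo sapiens) for inhibition, read by sulforhodamine B assay, with a stated time of 48 h (on this read-out higher numbers stand for weaker inhibition of growth and lower numbers for stronger inhibition of growth), are as follows.
- Compound 1 (`Fc1ccc(Cn2cc(CCCOc3cccc4cccnc34)nn2)cc1`): 11.7 ug/mL
- Compound 2 (`Fc1ccc(Cn2cc(CCCOc3cccc4cccnc34)nn2)cc1F`): 21.3 ug/mL

Among the compounds with values here, compound 2 stands within the scatter of compound 1, the only measured step being a 1.8-fold higher number from compound 1 to compound 2 (0.26 log units; within the scatter) and nothing more. Compound 3 (`c1cncc(CCCn2cc(CCCOc3cccc4cccnc34)nn2)c1`) remains unmeasured, and its change is a larger one: 2-(pyridin-3-yl)ethyl in place of 3,4-difluorophenyl on a saturated chain carbon bound to an aromatic nitrogen (2-(pyridin-3-yl)ethyl in place of 3,4-difluorophenyl). That measured step concerns fluoro in place of hydrogen on an aromatic carbon, so it bears on this change only loosely. Within the data shown here, no measured compound carries the entering group, and the data give no direction. The estimate therefore stays close to compound 2 at 21.3 ug/mL with a wide margin. The expected step is a 1.2-fold lower number from compound 2 to compound 3 (0.07 log units; within the scatter) and stays within the scatter. Compound 3 is estimated at 18 ug/mL (expected range 8 ug/mL to 42 ug/mL).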

Compound 3, concentration for 50% growth inhibition: 27.8 ug/mL
The estimate for compound 3 lay 1.5-fold (0.19 log units) below the measured number; the measured number falls inside the stated range.
By their numbers in this assay, from the lowest: compounds 1, 2 and 3 (each within the scatter of the next, the first and the last beyond it).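

In this assay the exchange of 3,4-difluorophenyl for 2-(pyridin-3-yl)ethyl gives a 1.3-fold higher number from compound 2 to compound 3 (0.12 log units; within the scatter) and so shows that this position, on a saturated chain carbon bound to an aromatic nitrogen, tolerates a ring with a hetero atom and a hydrogen-bond acceptor without a difference that can be told from the scatter. Set against 4-fluorophenyl, the same group gives a 2.4-fold higher number from compound 1 to compound 3 (0.38 log units; beyond the scatter) as the only step in the set beyond the scatter, and a modest one. Nothing measured alongside these growth-inhibition numbers offers an explanation for them.

The change alters both the ring and the chain, and these compounds do not separate the two. From the compounds shown here alone, whether a plain benzyl group, or an amine or a carboxylic acid at this position, would give a clearly different number remains open.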